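The compounds below may be only part of what the source reports. "The series", "measured", "known", "first", "only" and "open" are said of these compounds alone.

Measured compounds:
- compound 1, `Nc1n[nH]c2cc(-c3ccc(=O)n(Cc4cccc(Cl)c4)c3)ccc12`: 11 nM
- compound 2, `Nc1cccc(Cn2cc(-c3ccc4cn[nH]c4c3)ccc2=O)c1`: 287 nM

The study measured these compounds in an assay for inhibition of MAP kinase-interacting serine/threonine-protein kinase 1 (Homo sapiens), read by luminescence and ADP-Glo, with a stated time of 2 h; a higher number here means a weaker inhibitor, a lower number a stronger inhibitor. Compound 1, with its own core, gives 11 nM in this assay. Compound 2, built on a different core, gives 287 nM, the higher of the two numbers, and its gap to compound 1 lies beyond the scatter of the assay.

The next compound, compound 3, `O=c1ccc(-c2ccc3cn[nH]c3c2)cn1Cc1cccc(F)c1`, has not yet been measured in this assay. It differs from compound 2 in one place: fluoro in place of amino on an aromatic carbon. A hydrogen-bond donor and acceptor leave and a fluorine enters on the ring that carries the benzyl group.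

Going by the values given here, no step between two measured compounds matches this change, so the size of its effect is unknown. Compound 1, with a halogen on that same benzyl ring but a different core, gives 11 nM, which offers a loose hint but not a measured step. Compound 3 is therefore expected to give 150 nM, within 40 nM to 600 nM, a step from compound 2 to compound 3 of a 1.9-fold lower number from compound 2 to compound 3 (0.28 log units; within the scatter) that is expected to be small, toward a lower number, and possibly within the scatter.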

Compound 3, half-maximal inhibitory concentration: 74 nM
The estimate for compound 3 lay 2.0-fold (0.31 log units) above the measured number, and the stated range covers the measured number.
By their numbers in this assay, from the lowest: compound 1; then compound 3; then compound 2.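

In this assay, the first change in a single place among these compounds gives a 3.9-fold lower number from compound 2 to compound 3 (0.59 log units; beyond the scatter), which shows that the group at this position on the benzyl ring affects the read-out. Going from 3-aminobenzyl to 3-fluorobenzyl removes a hydrogen-bond donor and a hydrogen-bond acceptor from the ring, and inhibition does not suffer: the number falls rather than rises. No measurement shown here bears on the reason for this step.

Among the compounds shown, only amino and fluoro can be compared at this position on the shared core, so it remains open whether hydrogen, methoxy or a carboxylic acid there would follow the fluoro compound or the amino compound. Compound 1 differs from compound 3 in more than one place, so in this assay the contribution of the amino group on its core cannot be separated from that of chloro in place of fluoro on the benzyl ring.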